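The source may report more compounds than this note shows. Statements on the series, on what has been measured and on what is new or still open speak of the compounds shown alone.

Measured so far:
- compound 1, `Cc1c(F)c(Oc2cccc(CCC(=O)N(C)C)c2)nc(Oc2cccc(C(=N)N)c2)c1F`, 4900 nM
- compound 2, `Cc1c(F)c(Oc2cccc(C(=N)N)c2)nc(Oc2cc(O)cc(C(=O)N(C)C)c2)c1F`, 1900 nM
- compound 3, `Cc1c(F)c(Oc2cccc(C(=N)N)c2)nc(Oc2cc(C(=O)N(C)C)ccc2O)c1F`, 3700 nM

All three numbers come from an assay on isolated protein for inhibition of serine protease 1 (Bos taurus); on this read-out lower numbers stand for stronger inhibition and higher numbers for weaker inhibition. Compound 3 stands second highest of the three. Its nearest neighbour on the numbers is compound 1, and the gap between them lies within the usual scatter of repeated measurements. Compound 2 gives the furthest number from compound 3, and that gap too stays within the scatter, so nothing in these three values separates one compound from another with confidence.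

Compound 4, `COc1ccc(C(=O)N(C)C)cc1Oc1nc(Oc2cccc(C(=N)N)c2)c(F)c(C)c1F`, has not yet been measured in this assay. It differs from compound 3 in one place: methyl in place of hydrogen on an oxygen on an aromatic ring. Among the compounds with values here, no measured pair shows a step of this kind, so the expectation rests on how closely the three measured values sit together. With every gap among them inside the scatter, the most cautious expectation is that the step from compound 3 to compound 4 in this assay, a 1.2-fold higher number from compound 3 to compound 4 (0.09 log units; within the scatter), is estimated to stay within the scatter as well, with no clear direction. On that basis compound 4 is expected to give about 4500 nM in this assay, with a plausible range from 1500 nM to 14000 nM.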

Compound 4, inhibition constant: 2100 nM
For compound 4 the middle estimate is 2.1-fold (0.33 log units) above the measured one; the measured number falls inside the stated range.
By their numbers in this assay, from the lowest: compounds 2, 4, 3 and 1 (each within the scatter of the next, the first and the last beyond it).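

Replacing hydroxy with methoxy on this oxygen gives a 1.8-fold lower number from compound 3 to compound 4 (0.25 log units; within the scatter) in this assay, so the step cannot be told apart from repeat-measurement noise. Within the data shown here, this is the first pair here that differs in one place only, and it shows that the hydrogen on this oxygen can be swapped for a methyl without a change that this assay can resolve, although a small real shift in either direction cannot be excluded. Nothing available bears on why the step comes out this way.

The compounds shown leave open how much room this oxygen allows, since a single methyl is the only group tried on it here, and an ethyl, a longer chain, or a chain ending in an amine or a carboxylic acid could give a step that clears the scatter. They also leave open whether the same hydroxy to methoxy change would behave alike on compound 2, where the hydroxy sits elsewhere on the ring, so this one pair cannot yet be read as a rule for the series.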